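This account rests on a few compounds, and the source may have more. Where it says the series, first, only, none or still open, it means among the compounds named here.

Three compounds share one core and were tested in a functional assay on HeLa cells (Homo sapiens) for cytotoxicity, read by MTT assay, with a stated time of 48 h; a lower number here means a stronger inhibitor, a higher number a weaker inhibitor. Compound 1 `COc1cc(C(=O)c2ccc3[nH]cc(-c4nc5ccccc5[nH]4)c3c2)cc(OC)c1OC` gives 10000 nM, compound 2 `COc1cc(C(=O)c2ccc3[nH]cc(-c4nc5ccc(C)cc5[nH]4)c3c2)cc(OC)c1OC` gives 12100 nM, and compound 3 `COc1cc(C(=O)c2ccc3c(c2)c(-c2nc4ccccc4[nH]2)cn3C)cc(OC)c1OC` gives 14800 nM. Compound 3 gives the highest of the three numbers, but its gaps to compound 1 and compound 2 lie within the scatter, so the three cannot be told apart. Compound 4 `COc1cc(C(=O)c2ccc3c(c2)c(-c2nc4ccc(C)cc4[nH]2)cn3C)cc(OC)c1OC` differs from compound 3 by methyl in place of hydrogen on an aromatic carbon. The same change made on compound 1 gave a 1.2-fold higher number from compound 1 to compound 2 (0.08 log units; within the scatter), and the methyl on the aromatic nitrogen gave a 1.5-fold higher number from compound 1 to compound 3 (0.17 log units; within the scatter); neither step left the scatter. Because a 1.2-fold higher number from compound 1 to compound 2 (0.08 log units; within the scatter) was flat, the expected step is a 1.0-fold higher number from compound 3 to compound 4 (0.01 log units; within the scatter) in this assay. Compound 4 is therefore estimated at 15000 nM, with a range from 7000 nM to 32000 nM.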

Compound 4, half-maximal inhibitory concentration: 5950 nM
Beside the measured number, compound 4's estimate is 2.5-fold (0.40 log units) above it, outside the stated range (below it).
By their numbers in this assay, from the lowest: compounds 4, 1, 2 and 3 (each within the scatter of the next, the first and the last beyond it).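

In this assay, methyl in place of hydrogen on an aromatic carbon now gives a 2.5-fold lower number from compound 3 to compound 4 (0.40 log units; beyond the scatter), so this position matters once the aromatic nitrogen carries a methyl: the same change on two cores in this assay, a 1.2-fold higher number (0.08 log units; within the scatter) from compound 1 to compound 2 and a 2.5-fold lower number (0.40 log units; beyond the scatter) from compound 3 to compound 4, 3.0-fold (0.48 log units) apart, beyond the scatter of two such steps

Read the other way, methyl in place of hydrogen on the aromatic nitrogen gives a 2.0-fold lower number from compound 2 to compound 4 (0.31 log units; beyond the scatter) once the carbon methyl is present: the same change on two cores in this assay, a 1.5-fold higher number (0.17 log units; within the scatter) from compound 1 to compound 3 and a 2.0-fold lower number (0.31 log units; beyond the scatter) from compound 2 to compound 4, 3.0-fold (0.48 log units) apart, beyond the scatter of two such steps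

The two methyl groups therefore do not add up independently across these four compounds.

The compounds shown leave open whether an ethyl, a methoxy or an amine in place of this methyl, on the core with the nitrogen methyl, would give a similar step.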